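Swapping the benzothiophene for a cyanobenzyl group

This account rests on a few compounds, and the source may have more. Where it says the series, first, only, none or still open, it means among the compounds named here.

Measured compounds:
- compound 1 `O=C1OC(c2ccc3ccccc3n2)CN1C1CCN(Cc2cc3ccccc3[nH]2)CC1`: < 50200 nM
- compound 2 `COc1ccc2nccc(C3CN(C4CCN(Cc5cc6ccccc6s5)CC4)C(=O)O3)c2c1`: 794 nM

For the measured compounds named here, in an in vitro functional assay on RBL cells for antagonist activity at C-C chemokine receptor type 8 (Homo sapiens), read by FLIPR and calcium flux (on this read-out higher numbers stand for weaker inhibition and lower numbers for stronger inhibition), compound 2 gives 794 nM, the only number among the values shown. The value of compound 1 is a limit of this assay the limit of < 50200 nM in this assay, at which 1 of the 2 values shown sits, and not a number. Compound 3 `COc1ccc2nccc(C3CN(C4CCN(Cc5ccc(C#N)cc5)CC4)C(=O)O3)c2c1` differs from compound 2 at one place: 4-cyanophenyl in place of 1-benzothiophen-2-yl on a saturated chain carbon bound to an amine nitrogen in a ring. Going by the values given here, no pair of measured compounds differing in one place is at hand, so the size of this step can only be estimated. The account expects a loss of inhibition beyond the usual scatter for compound 3, with a step of a 3.1-fold higher number from compound 2 to compound 3 (0.50 log units; beyond the scatter) in this assay. Compound 3 is estimated at 2500 nM, with a range from 600 nM to 10000 nM.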

Compound 3, half-maximal inhibitory concentration: 12600 nM
Compound 3: the middle estimate sits 5.0-fold (0.70 log units) below what was measured; the measured number lies above the stated range.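

In this assay, the group on the saturated chain carbon bound to an amine nitrogen in a ring proves to matter strongly: 4-cyanophenyl in place of 1-benzothiophen-2-yl gives a 16-fold higher number from compound 2 to compound 3 (1.20 log units; beyond the scatter) and thus a large loss of inhibition. For the compounds shown here, this is the first step that can be read at this place, and it shows that the shared core alone does not secure the inhibition, as one exchange of this group takes away much of it. Nothing shown here accounts for the size of this step.

As far as these compounds go, it remains open whether the loss goes with the nitrile or with the departure of the five-membered aromatic ring. Also open, from the compounds shown here alone, is how a plain benzyl group, a 4-methoxybenzyl group or a (1-benzofuran-2-yl)methyl group would stand at this place.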